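Benzylamide in place of methyl ester on the shared core

A few compounds are considered here, and "the series" means these few. Any claim that something is new, unique, unknown or untested is made for them only; others in the source may bear on it.

Of the compounds shown here, two have been measured in an assay on HEK293 cells for inhibition of Voltage-dependent N-type calcium channel subunit alpha-1B (Homo sapiens), tested at 10 uM; on this read-out lower numbers stand for less inhibition and higher numbers for more inhibition at the one concentration tested (going by the name of the read-out). Compound 1 `NCCCCCNC1=Nc2ccccc2C(CC(=O)NCc2ccccc2)N1c1ccc(-c2ccccc2)cc1` gives 8.3% in this assay, while compound 2 `COC(=O)CC1c2ccccc2N=C(NCCCCCNC(=O)OC(C)(C)C)N1c1ccc(-c2ccccc2)cc1` gives 98.6% in this assay, the highest of the two numbers and far beyond the scatter from compound 1. Compound 1 and compound 2 differ in more than one place, so their values show only the spread across the pair, not a single step.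

Compound 3 `CC(C)(C)OC(=O)NCCCCCNC1=Nc2ccccc2C(CC(=O)NCc2ccccc2)N1c1ccc(-c2ccccc2)cc1` is not yet measured. It differs from compound 2 by benzylamino in place of methoxy on a carbonyl carbon. Compound 3 shares the benzylcarbamoyl group with compound 1 and the remaining chain substitution with compound 2, so the expected step in this assay, a number 38.6 percentage points lower from compound 2 to compound 3 (beyond the scatter), is a loss, because compound 1, which carries that group, gives only 8.3%. For compound 3 the estimate in this assay is 60%, within 15% to 95%.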

Compound 3, a percentage reported as inhibition, at one concentration (the size of the read-out at that concentration, not a potency): 16.6%
Compound 3: the middle estimate sits 43.4 percentage points above what was measured, and the stated range covers the measured number.
By their numbers in this assay, from the lowest: compounds 1 and 3 (each within the scatter of the next); then compound 2.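

In this assay, benzylamino in place of methoxy on a carbonyl carbon now stands as a change in one place, and it gives a large loss: a number 82 percentage points lower from compound 2 to compound 3 (beyond the scatter). With benzylcarbamoyl held constant, tert-butoxycarbonyl in place of hydrogen on an amine nitrogen gives a number 8.3 percentage points higher from compound 1 to compound 3 (within the scatter), so this change does not recover the loss in this series. No measured property is available that bears on the cause of the loss.

As far as these compounds go, it remains open whether the loss follows the benzyl group or the amide hydrogen; a methylamino or dimethylamino group, or a carboxylic acid, on the same carbonyl carbon would help separate these. From the compounds shown here alone, it also remains open whether the free amine keeps the high reading when paired with methoxycarbonyl.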